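Lipophilicity notes: benzofuran replacement on the benzylic arm

The source may report more compounds than this note shows. Statements on the series, on what has been measured and on what is new or still open speak of the compounds shown alone.

Measured so far:
compound 1 `CNC(=O)c1cc(C(=O)NC2CC2)cn(Cc2cccc([C@@H](C)O)c2)c1=O` — 2.2
compound 2 `CNC(=O)c1cc(C(=O)NC)c(=O)n(Cc2ccccc2)c1` — 2.4
compound 3 `CCNC(=O)c1cccn(Cc2ccccc2)c1=O` — 3.7

In a physicochemical assay for lipophilicity, at pH 7.4 (a lower number here means a more polar compound, a higher number a more lipophilic compound), compound 1 stands lowest of the three numbers. Its nearest neighbour is compound 2, whose value in this assay sits within the scatter of that of compound 1, so no order between these two can be read. Compound 3 is the furthest away, and its value in this assay lies beyond the scatter above compound 1; compound 3 is the most lipophilic of the three on the numbers shown.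

The next compound, compound 4 `CNC(=O)c1cc(C(=O)NC2CC2)cn(Cc2cccc3occc23)c1=O`, has not yet been measured in this assay. It differs from compound 1 in one place: 1-benzofuran-4-yl in place of 3-(1-hydroxyethyl)phenyl on a saturated chain carbon bound to an aromatic nitrogen. The group that leaves carries the only hydrogen-bond donor of that side chain; the group that enters carries none and adds a second aromatic ring. For the measured compounds named here, no step between two measured compounds describes this exchange directly. The expectation is that compound 4 moves upward, by a step of a number 0.80 log units higher from compound 1 to compound 4 (beyond the scatter) that goes beyond the scatter. On that basis compound 4 is estimated at 3, with a range from 2.5 to 3.5.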

Compound 4, distribution coefficient: 3.4
For compound 4 the middle estimate is 0.40 log units below the measured one, and the stated range covers the measured number.
By their numbers in this assay, from the lowest: compounds 1 and 2 (each within the scatter of the next); then compounds 4 and 3 (each within the scatter of the next).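

In this assay the exchange of 3-(1-hydroxyethyl)phenyl for 1-benzofuran-4-yl on a saturated chain carbon bound to an aromatic nitrogen gives a number 1.20 log units higher from compound 1 to compound 4 (beyond the scatter) and this step is large. It is the only step shown at this position, and it shows that the number can move well beyond the scatter with 9 heavy atoms leaving and 9 entering, while the hydrogen-bond donor and the defined stereocentre go and a five-membered aromatic ring comes in. Nothing at hand assigns the step to any one of these differences.

The compounds shown do not separate the loss of the hydrogen-bond donor from the gain of the second aromatic ring. Also open, on these data alone, is where an amine or a carboxylic acid on this arm of the shared core would fall in this assay on the same scale.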